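Lipophilicity notes: one stereocentre redrawn

A few compounds are considered here, and "the series" means these few. Any claim that something is new, unique, unknown or untested is made for them only; others in the source may bear on it.

Measured in a physicochemical assay for lipophilicity, at pH 7.4; on this read-out higher numbers stand for higher lipophilicity and lower numbers for lower lipophilicity
- compound 1 `C[C@H]1C(=O)N(C)C=C(c2cn[nH]c2)c2cc([C@@H](O)CO)ccc21` at 0.9
- compound 2 `C[C@H]1C(=O)N(C)C=C(c2cnn(C)c2)c2cc([C@H](O)CO)ccc21` at 1.3

Compound 2 holds the higher of the two numbers, and compound 1 lies lower by more than the usual scatter. Compound 3 `C[C@H]1C(=O)N(C)C=C(c2cnn(C)c2)c2cc([C@@H](O)CO)ccc21` has not yet been measured. Its structure departs from that of compound 2 by the two compounds have the same atoms and bonds and differ only in configuration as drawn: 1 of 2 stereo elements differ; a stereocentre at a saturated chain carbon is drawn S in compound 2 and R in compound 3 in configuration only: the two compounds have the same atoms and bonds, and a stereocentre at a saturated chain carbon is drawn S in compound 2 and R in compound 3. Within the data shown here, no measured pair shows a change of this kind, so the expectation rests on compound 2 at 1.3 and on the unchanged atoms and bonds. No step beyond the scatter is expected in this assay, in either direction. The estimated change is no change at the digits printed from compound 2 to compound 3 (within the scatter) in size. Compound 3 is estimated at 1.3 (expected range 1 to 1.6).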

Compound 3, distribution coefficient: 1.3
For compound 3 middle estimate and measured number coincide at the digits printed; measured number inside the range.
By their numbers in this assay, from the lowest: compound 1; then compounds 2 and 3 (each within the scatter of the next).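

In this assay, redrawing the stereocentre at a saturated chain carbon from S to R gives no change at the digits printed from compound 2 to compound 3 (within the scatter), so in this series the read-out does not separate the two drawn configurations at this position. With that configuration matched, methyl in place of hydrogen on an aromatic nitrogen gives a number 0.40 log units higher from compound 1 to compound 3 (beyond the scatter), a comparison in one place that the earlier pair, differing in two places, could not supply. The flat result at the stereocentre has to be read with one fact in mind: the fact that compounds 2 and 3 differ only in the configuration as drawn.

Still open, as far as these compounds go, is whether an ethyl or cyclopropyl group on that aromatic nitrogen would extend the step seen with methyl. Also open, from the compounds shown here alone, is whether the two configurations would still match with an amine or a carboxylic acid in place of the hydroxyl on the chain.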